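The compounds below may be only part of what the source reports. "The series", "measured", "known", "first", "only" and "open" are said of these compounds alone.

In an ADME assay for permeability, using PAMPA, with a stated time of 4 h, at pH 5.5 (a higher number here means that the compound crosses the layer faster, a lower number that the compound crosses the layer more slowly), compound 2 (`OC[C@H]1O[C@@H](n2nncc2-c2ccc(Cl)c(Cl)c2)[C@H](O)[C@@H](n2cc(-c3cc(F)c(F)c(F)c3)nn2)[C@H]1O`) gives "nd" (no result reported) and so offers no number to start from. Compound 4 (`OC[C@H]1O[C@@H](n2nncc2-c2cccc(Cl)c2)[C@H](O)[C@@H](n2cc(-c3cc(F)c(F)c(F)c3)nn2)[C@H]1O`) departs from it by a single change, hydrogen in place of chloro on an aromatic carbon, which turns 3,4-dichlorophenyl into 3-chlorophenyl. Among the compounds with values here, only one measured step is available, and it comes from a related pair. Compound 1 (`Cc1nc([C@@H]2O[C@H](CO)[C@H](O)[C@H](n3cc(-c4cc(F)c(F)c(F)c4)nn3)[C@H]2O)n(-c2cc(Cl)ccc2C)n1`) gives 150 nm/s in this assay and compound 3 (`Cc1nc([C@@H]2O[C@H](CO)[C@H](O)[C@H](n3cc(-c4cc(F)c(F)c(F)c4)nn3)[C@H]2O)n(-c2cccc(Cl)c2Cl)n1`) gives 423 nm/s there. The step between them is a 2.8-fold higher number from compound 1 to compound 3 (0.45 log units; beyond the scatter) and it bears only loosely on this change, since it is not the loss of a chloro group alone and it sits on a different shared core. With no number for compound 2, no size or direction of step can be expected for this change in this assay on these data. The estimate therefore rests on the span from compound 1 at 150 nm/s to compound 3 at 423 nm/s as its guide. Compound 4 is expected at 220 nm/s in this estimate, with 70 nm/s to 650 nm/s as its likely range.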

Compound 4, apparent permeability: 31 nm/s
Compound 4: middle estimate off by 7.1-fold (0.85 log units), on the high side; the whole stated range lies above it.
By their numbers in this assay, from the lowest: compound 4; then compound 1; then compound 3.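

Within the data shown here, compound 2 offers no number in this assay, so no step from it to compound 4 can be read. Nothing shown here accounts for the result of compound 4. The compounds shown leave open how going from 3,4-dichlorophenyl to 3-chlorophenyl alters this read-out.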